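The compounds below may be only part of what the source reports. "The series", "measured", "known", "first", "only" and "open" are said of these compounds alone.

Measured so far in a functional assay on DU-145 cells (Homo sapiens) for inhibition, read by trypan blue exclusion, with a stated time of 96 h; a lower number here means a stronger inhibitor of growth, a higher number a weaker inhibitor of growth:
compound 1 `CSc1ccc(/C=C(\C(=O)c2ccc(Cl)cc2)S(=O)(=O)Cc2ccc(C)cc2)cc1`: 10000 nM
compound 2 `Cc1ccc(/C=C(\C(=O)c2ccc(Cl)cc2)S(=O)(=O)Cc2ccc(F)cc2)s1`: 50000 nM
compound 3 `Cc1ccc(/C=C(\C(=O)c2ccc(Br)cc2)S(=O)(=O)Cc2ccc(F)cc2)s1`: 1000 nM

Compound 1 and compound 2 differ in more than one place; the difference between the two cores is not broken down here. Compound 1 stands between the other two: compound 2 gives a higher number and compound 3 a lower one in this assay.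

Compound 2 and compound 3 share a core and differ in one place, (bromo in place of chloro on an aromatic carbon). That change made a 50-fold lower number from compound 2 to compound 3 (1.70 log units; beyond the scatter).

Compound 4 `CSc1ccc(/C=C(\C(=O)c2ccc(Br)cc2)S(=O)(=O)Cc2ccc(C)cc2)cc1` is not yet measured. It stands to compound 1 as compound 3 stands to compound 2: the change is bromo in place of chloro on an aromatic carbon, the same change at the same kind of place, made on the core of compound 1 instead of the core of compound 2.

The expectation for compound 4 rests on a single precedent, so the step for compound 4 is expected to be smaller than the one observed, namely a 10-fold lower number from compound 1 to compound 4 (1.00 log units; beyond the scatter), because in a 50-fold lower number from compound 2 to compound 3 (1.70 log units; beyond the scatter) the direction was a clear drop in number. Compound 4 is therefore expected to give about 1000 nM in this assay, estimated to fall between 200 nM and 6000 nM.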

Compound 4, concentration for 50% growth inhibition: 10000 nM
Beside the measured number, compound 4's estimate is 10-fold (1.00 log units) below it; measured number above the stated range.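

In this assay, bromo in place of chloro on an aromatic carbon gives no change at the digits printed from compound 1 to compound 4 (within the scatter). The same change does not give the same step on the two cores: the same change on two cores in this assay, a 50-fold lower number (1.70 log units; beyond the scatter) from compound 2 to compound 3 and no change at the digits printed (within the scatter) from compound 1 to compound 4, 50-fold (1.70 log units) apart, beyond the scatter of two such steps

With one pair on each core, the large step on the core of compound 2 cannot be taken as a general effect of this change across the series, though these two pairs do not show which of the several differences in the cores accounts for the gap, or how the change would behave on a third core.

Still open, on these data alone, is how the step would run on a core combining parts of the core of compound 1 with parts of the core of compound 2, which could narrow down the part that matters. Also open, as far as these compounds go, is how the values would respond to an amine or a carboxylic acid in place of the halogen on that aromatic ring.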